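Hydroxy for carbamoyl on a cyclopropanecarboxamide side chain

The compounds below may be only part of what the source reports. "The series", "measured", "known", "first", "only" and "open" are said of these compounds alone.

Measured so far in a functional assay on the whole organism with Mus musculus as the target; on this read-out lower numbers stand for an effect already at smaller amounts and higher numbers for an effect only at larger amounts of compound:
Compound 1 `CNC(=O)C1C(C)(C)C1(C)C` gives 98 mg/kg.
Compound 2 `CC1(C)C(C(=O)NCC(N)=O)C1(C)C` gives 173 mg/kg.

Compound 2 sits within the scatter of compound 1, as a 1.8-fold higher number from compound 1 to compound 2 (0.25 log units; within the scatter) shows. Compound 3 `CC1(C)C(C(=O)NCO)C1(C)C` differs from compound 2 by hydroxy in place of carbamoyl on a saturated chain carbon bound to an amide-type nitrogen. For the measured compounds named here, the only step that touches this place is the one from compound 1 to compound 2, which stayed within the scatter, so no step beyond the scatter is expected in this assay. Compound 3 is therefore expected to give about 150 mg/kg, between 70 mg/kg and 330 mg/kg, meaning a 1.2-fold lower number from compound 2 to compound 3 (0.06 log units; within the scatter).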

Compound 3, dose for half-maximal effect: > 220 mg/kg
Compound 3: a limit, no number (the forecaster's own chance of this, stated with the estimate: 10%); at least 1.4-fold (0.16 log units) between middle value and limit.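

Compound 3 gives a limit of the assay, not a number: the limit of > 220 mg/kg in this assay, at which 1 of the 3 values shown sits.

Hydroxy in place of carbamoyl gives an at least 1.2-fold higher number from compound 2 to compound 3 (0.10 log units; that floor lies within the scatter), so this floor does not separate the two groups. Hydroxy in place of hydrogen on this saturated chain carbon gives an at least 2.2-fold higher number from compound 1 to compound 3 (0.35 log units; beyond the scatter), the first step in this series beyond the scatter, whereas carbamoyl in the same place stayed within it.

On these data alone, how far compound 3 truly lies from compound 2 in this assay remains open. So does whether an amine, a carboxylic acid or a longer chain in this place would behave like hydroxy or like carbamoyl.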